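The source may hold more compounds than are shown below. What is called first, only, known or untested is meant among the compounds shown, and "the series" means these compounds.

Compound 1 `CN(c1cccc2c1CN(c1nc(Nc3cc(C(F)(F)F)cc(C(F)(F)F)c3)ncc1C(F)(F)F)C2)S(C)(=O)=O` gives in a functional assay on OVCAR-3 cells (Homo sapiens) for antiproliferative activity, read by spectrophotometry, with a stated time of 2 days (on this read-out higher numbers stand for weaker inhibition of growth and lower numbers for stronger inhibition of growth), only a limit, > 30000 nM.
Compound 2 `CN(c1cccc2c1CN(c1nc(Nc3cccc(C(F)(F)F)c3)ncc1C(F)(F)F)C2)S(C)(=O)=O` gives in this assay only a limit, > 30000 nM.
Compound 3 `CN(c1cccc2c1CN(c1nc(Nc3cccc(Oc4ccccc4)c3)ncc1C(F)(F)F)C2)S(C)(=O)=O` gives in this assay 24900 nM.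

Compound 2 thus stands at the edge of what this assay can report: its value is a limit and not a number, and it shares that position with compound 1, as the limit of > 30000 nM in this assay, at which 2 of the 3 values shown sit, shows, while compound 3 alone carries a measured number, and that number lies close to the same edge. The piece now follows the step from compound 2 to compound 4 `COc1cc(Nc2ncc(C(F)(F)F)c(N3Cc4cccc(N(C)S(C)(=O)=O)c4C3)n2)cc(C(F)(F)F)c1`, a change on the aromatic ring that carries the trifluoromethyl group: methoxy in place of hydrogen on an aromatic carbon.

For the measured compounds named here, two measured steps touch this part of the structure. The first, a step that the two limits leave unreadable from compound 1 to compound 2, cannot be read, since both of its ends are limits. The second, an at least 1.2-fold lower number from compound 2 to compound 3 (0.08 log units; that floor lies within the scatter), is only a floor, and that floor lies within the scatter. Neither step therefore supplies evidence that a substituent on this ring moves the read-out in either direction by more than the scatter, and nothing in the shown data points to a gain in growth inhibition.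

On this basis compound 4 is expected to sit near the limit of this assay, with a fair chance that only a limit is returned; its estimated value is 30000 nM, with a range from 12000 nM to 70000 nM. The expected step is a number no higher from compound 2 to compound 4 (the limit leaves the size open), that is, no change beyond the scatter.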

Compound 4, concentration for 50% growth inhibition: > 30000 nM
Compound 4: a limit, no number (the forecaster's own chance of this, stated with the estimate: 55%); the middle value lies on the limit itself.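

In this assay compound 4 gives only a limit (> 30000 nM), so its steps from compound 1 and compound 2, which are limits as well, cannot be read. The compounds shown leave open whether methoxy in place of hydrogen on this ring moves the read-out in either direction, as most values remain at the assay's edge: the limit of > 30000 nM in this assay, at which 3 of the 4 values shown sit.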